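The source may hold more compounds than are shown below. What is called first, only, known or untested is meant among the compounds shown, and "the series" means these compounds.

In a functional assay on A549 cells (Homo sapiens) for cytotoxicity, read by sulforhodamine B assay, with a stated time of 72 h; a higher number here means a weaker inhibitor, a lower number a stronger inhibitor:
compound 1 `CCS(=O)(=O)Nc1cc(-c2ccc3ncnc(Nc4ccc(F)cc4F)c3c2)cnc1OC` gives 4710 nM
compound 2 `CCS(=O)(=O)Nc1cc(-c2ccc3ncnc(Nc4ccc(OC)c(Cl)c4)c3c2)cnc1OC` gives 5240 nM

For the measured compounds named here, compound 2 sits alongside compound 1: the only measured step, a 1.1-fold higher number from compound 1 to compound 2 (0.05 log units; within the scatter), lies within the scatter, so the two numbers are not separable.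

Compound 3 `CCS(=O)(=O)Nc1cc(-c2ccc3ncnc(Nc4cccc(C(=O)OC)c4)c3c2)cnc1OC` differs from compound 2 by 3-(methoxycarbonyl)phenyl in place of 3-chloro-4-methoxyphenyl on a nitrogen on an aromatic ring. Going by the values given here, the one step that bears on this change is the earlier exchange of the group on the same nitrogen, a 1.1-fold higher number from compound 1 to compound 2 (0.05 log units; within the scatter), which left the number essentially unchanged. A further aryl exchange at that place is therefore expected to give no step beyond the scatter in this assay. Compound 3 is expected at 5000 nM, with a range from 2000 nM to 13000 nM. The expected step is a 1.0-fold lower number from compound 2 to compound 3 (0.02 log units; within the scatter).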

Compound 3, half-maximal inhibitory concentration: 1100 nM
Estimate against measurement, compound 3: 4.5-fold (0.66 log units) above; measured number outside the range, below it.
By their numbers in this assay, from the lowest: compound 3; then compounds 1 and 2 (each within the scatter of the next).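

In this assay the aryl group on the nitrogen does move the number: 3-(methoxycarbonyl)phenyl gives a 4.8-fold lower number from compound 2 to compound 3 (0.68 log units; beyond the scatter) against 3-chloro-4-methoxyphenyl and a 4.3-fold lower number from compound 1 to compound 3 (0.63 log units; beyond the scatter) against 2,4-difluorophenyl, while those two groups stay within the scatter of each other. So this position is not indifferent to the aryl exchange, as compound 1 and compound 2 alone had suggested. Nothing measured here accounts for the step.

Open, as far as these compounds go, is whether the methoxycarbonyl group itself carries the step. A carboxylic acid or a primary amide in its place would test that.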